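The source may hold more compounds than are shown below. What is called first, only, known or untested is meant among the compounds shown, and "the series" means these compounds.

Three compounds with a shared core have been measured in an assay on CHO cells for displacement of a labelled ligand from adenosine receptor A1 (Homo sapiens), tested at 10 uM; a lower number here means less inhibition, a higher number more inhibition at the concentration tested (going by the name of the read-out):

compound 1 `CC(=O)Nc1nn(-c2ccccc2)c(=O)c2ccccc12` gives 52%
compound 2 `COc1ccc(OC)c(NC(=O)Nc2nn(-c3ccccc3)c(=O)c3ccccc23)c1` gives 0%
compound 3 `O=C(Nc1nn(-c2ccccc2)c(=O)c2ccccc12)c1ccc(Cl)cc1` gives 26%

Compound 2 stands lowest of these three in this assay. Its nearest neighbour is compound 3, whose number lies higher by a margin beyond the scatter, and the furthest is compound 1, higher still and also beyond the scatter. Compound 4 `COc1ccccc1NC(=O)Nc1nn(-c2ccccc2)c(=O)c2ccccc12` is not yet measured. It differs from compound 2 in one place: hydrogen in place of methoxy on an aromatic carbon. Cut one bond further out, the change reads 2,5-dimethoxyphenyl to 2-methoxyphenyl.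

Among the measured compounds shown here, only one measured step connects two compounds that differ in one place, a number 26 percentage points lower from compound 1 to compound 3 (beyond the scatter), a modest fall brought about on the carbonyl carbon rather than on the aromatic ring carrying the methoxy groups. For the measured compounds named here, no measured pair shows what removing a methoxy from that ring does, so the expectation for compound 4 rests on compound 2 alone. The account therefore expects a step within the scatter, in no particular direction, a number 10 percentage points higher from compound 2 to compound 4 (within the scatter). Compound 4 is estimated at 10%, expected to fall between 0% and 30%.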

Compound 4, a percentage reported as inhibition, at one concentration (the size of the read-out at that concentration, not a potency): 0%
For compound 4 the middle estimate is 10 percentage points above the measured one; the range from low to high includes it.
By their numbers in this assay, from the lowest: compounds 2 and 4 (each within the scatter of the next); then compound 3; then compound 1.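

In this assay, among the compounds shown here, the step of no change at the digits printed from compound 2 to compound 4 (within the scatter) is the first reading of a change on the ring carrying the methoxy groups: removing the methoxy that sits meta to a large group and para to a methoxy group, which turns 2,5-dimethoxyphenyl into 2-methoxyphenyl, has no effect that this assay can show. The group on the carbonyl carbon, by contrast, clearly counts, since (2-methoxyphenyl)amino in place of 4-chlorophenyl gives a number 26 percentage points lower from compound 3 to compound 4 (beyond the scatter) and the same group in place of methyl gives a number 52 percentage points lower from compound 1 to compound 4 (beyond the scatter), so among these four compounds the two bearing the methoxyphenyl amino group read lowest. No measurement shown here bears on why the numbers fall this way.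

As far as these compounds go, compound 2 and compound 4 both read at the bottom of the scale, so it remains open whether a change on this ring would register on a compound with a higher reading, and whether the remaining methoxy matters at all, as an unsubstituted phenyl or an amine on that ring would show. From the compounds shown here alone, it also remains open how far the number on the carbonyl carbon moves with a longer chain such as propyl in place of methyl, or with a carboxylic acid on the 4-chlorophenyl ring.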